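The source may hold more compounds than are shown below. What is called first, only, known or untested is meant among the compounds shown, and "the series" means these compounds.

Measured in an ADME assay on Vero cells (Chlorocebus sabaeus) for cytotoxicity; on this read-out lower numbers stand for higher toxicity in this test and higher numbers for lower toxicity in this test:
compound 1 `Cc1ccc2c(c1)C(=O)C(=O)N2Cc1cn(CC(=O)N2CCN(c3cc4c(cc3F)c(=O)c(C(=O)O)cn4C3CC3)CC2)nn1`: 16 ug/mL
compound 2 `CO/N=C1/C(=O)N(Cc2cn(CC(=O)N3CCN(c4cc5c(cc4F)c(=O)c(C(=O)O)cn5C4CC4)CC3)nn2)c2ccccc21`: 128 ug/mL
compound 3 `CO/N=C1/C(=O)N(Cc2cn(CC(=O)N3CCN(c4cc5c(cc4F)c(=O)c(C(=O)O)cn5C4CC4)CC3)nn2)c2c(F)cccc21`: 32 ug/mL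

Of these three numbers compound 3 holds the second highest. Compound 1 and compound 3 lie within the scatter of each other, so no order between them can be read. Compound 2 stands apart: a 4.0-fold lower number from compound 2 to compound 3 (0.60 log units; beyond the scatter) is beyond the scatter. Compound 4 `CCO/N=C1/C(=O)N(Cc2cn(CC(=O)N3CCN(c4cc5c(cc4F)c(=O)c(C(=O)O)cn5C4CC4)CC3)nn2)c2c(F)cccc21` differs from compound 3 by methyl in place of hydrogen on a saturated chain carbon bound to an oxygen on an unsaturated carbon. Among the compounds with values here, the one measured step, a 4.0-fold lower number from compound 2 to compound 3 (0.60 log units; beyond the scatter), concerns a fluoro on an aromatic carbon and says nothing about lengthening the chain on the oxygen, so no measured step bears on this change. The step of no change at the digits printed from compound 3 to compound 4 (within the scatter) is therefore expected to stay within the scatter. For compound 4 the estimate in this assay is 32 ug/mL, within 16 ug/mL to 64 ug/mL.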

Compound 4, half-maximal cytotoxic concentration: 16 ug/mL
Compound 4: the middle estimate sits 2.0-fold (0.30 log units) above what was measured; low and high end bracket the measured number.
By their numbers in this assay, from the lowest: compounds 1, 4 and 3 (each within the scatter of the next); then compound 2.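

Going from methoxy to ethoxy gives a 2.0-fold lower number from compound 3 to compound 4 (0.30 log units; within the scatter) in this assay, so no difference can be read between the two compounds. At this position on the oxygen, the added methyl therefore leaves the cytotoxicity read-out indistinguishable from that of the smaller group. Nothing shown here gives a reason for this result.

Still open, from the compounds shown here alone, is whether a longer chain such as propyl, or a chain carrying an amine or a carboxylic acid, would also stay within the scatter. Whether ethoxy would behave the same way without the fluoro, on the frame of compound 2, is also unanswered.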